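Swapping the fluorophenyl ring in a weak oxadiazoline analogue

This account rests on a few compounds, and the source may have more. Where it says the series, first, only, none or still open, it means among the compounds named here.

Measured compounds:
- compound 1, `COc1cc(C(=O)N/N=C/c2ccc(F)c(F)c2)cc(OC)c1OC`: 43.7%
- compound 2, `COc1cc(C2=NN(C(C)=O)C(c3ccc(F)cc3)O2)cc(OC)c1OC`: 0.1%
- compound 3, `COc1cccc(/C=N/NC(=O)c2cc(OC)c(OC)c(OC)c2)c1OC`: 67%

Three compounds sharing a trimethoxyphenyl group were tested in a functional assay on PC-3 cells (Homo sapiens) for antiproliferative activity, read by MTT assay, tested at 5 uM; on this read-out lower numbers stand for a weaker effect and higher numbers for a stronger effect at the one concentration tested. Compound 1 gives 43.7% and compound 3 gives 67%, both built around an acylhydrazone linker. Compound 2, which instead carries its aryl groups on a five-membered non-aromatic ring bearing an acetyl group, gives 0.1% in this assay. That is the lowest of the three numbers: the nearest, compound 1, lies higher by a gap beyond the scatter, and the furthest, compound 3, lies higher still, again beyond the scatter.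

Compound 4, `COc1cc(C2=NN(C(C)=O)C(c3cccc(C(F)(F)F)c3)O2)cc(OC)c1OC`, has not yet been measured. It differs from compound 2 in one place: 3-(trifluoromethyl)phenyl in place of 4-fluorophenyl on a saturated ring carbon. Within the data shown here, no pair of measured compounds differing in one place is available, so the size of this step has no direct precedent in the data. Compound 2 sits almost at the floor of the read-out, so a fall beyond the scatter is hardly possible; a modest rise, or no change beyond the scatter, seems the more likely outcome. For compound 4 the estimate in this assay is 10%, with a range of 0% to 35%, which would mean an expected step of a number 9.9 percentage points higher from compound 2 to compound 4 (within the scatter).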

Compound 4, a percentage reported as inhibition, at one concentration (the size of the read-out at that concentration, not a potency): 43.6%
Compound 4: the middle estimate sits 33.6 percentage points below what was measured; measured number above the stated range.
By their numbers in this assay, from the lowest: compound 2; then compounds 4 and 1 (each within the scatter of the next); then compound 3.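

In this assay, the aryl group on the saturated ring carbon proves to be a position that matters: 3-(trifluoromethyl)phenyl in place of 4-fluorophenyl gives a number 43.5 percentage points higher from compound 2 to compound 4 (beyond the scatter), a large step. Compound 4 keeps the five-membered non-aromatic ring and its acetyl group. It differs from compound 2 only in this aryl group. Nothing in the data given accounts for the size of the step, so it stands here as an observation only.

This single change alters both the substituent and its place on the phenyl ring, so the compounds shown cannot say which of the two carries the step. They also leave open how this position would respond to a nitrile, a chlorine atom or an amine on the phenyl ring, and whether a longer acyl chain in place of the acetyl group would change the picture.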